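The source may report more compounds than this note shows. Statements on the series, on what has been measured and on what is new or still open speak of the compounds shown alone.

Measured compounds in an assay on isolated protein for displacement of a labelled ligand from melanin-concentrating hormone receptor 1 (Homo sapiens); on this read-out higher numbers stand for weaker inhibition and lower numbers for stronger inhibition:
compound 1 `O=C(CCc1ccc(C(F)(F)F)cc1)Nc1ccc2nc(N3CCC(c4ccccc4)C3)ccc2c1` — 25 nM
compound 2 `CC(C)C(=O)NC1CCN(c2ccc3cc(NC(=O)CCc4ccc(C(F)(F)F)cc4)ccc3n2)C1` — 1 nM
compound 3 `O=C(CCCCCCCCCCCCc1ccc(C(F)(F)F)cc1)Nc1ccc2nc([N+]34CCC(CC3)CC4)ccc2c1` — 5 nM

Compound 2 gives the lowest number of the three in this assay; compound 3 stands nearest to it and compound 1 furthest, both gaps beyond the scatter. Compound 4 `CCN(CC)c1ccc2cc(NC(=O)CCc3ccc(C(F)(F)F)cc3)ccc2n1` is not yet measured. It differs from compound 2 in one place: diethylamino in place of 3-((isopropylcarbonyl)amino)pyrrolidin-1-yl on an aromatic carbon. Among the measured compounds shown here, the one measured step that bears on this change is a 25-fold lower number from compound 1 to compound 2 (1.40 log units; beyond the scatter), which shows how much the (isopropylcarbonyl)amino group on the five-membered ring contributes while that ring is kept. In compound 4 both the group and the ring are gone, and only a diethylamino group remains on the aromatic carbon next to the ring nitrogen. For the measured compounds named here, no measured pair shows what losing the ring itself does, so the expectation rests on that single step and carries a wide range. Compound 4 is therefore expected to give a higher number than compound 2, a step of a 30-fold higher number from compound 2 to compound 4 (1.48 log units; beyond the scatter). For compound 4 the estimate is 30 nM, between 8 nM and 120 nM.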

Compound 4, half-maximal inhibitory concentration: 88 nM
Compound 4: middle estimate off by 2.9-fold (0.47 log units), on the low side; low and high end bracket the measured number.
By their numbers in this assay, from the lowest: compound 2; then compound 3; then compound 1; then compound 4.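

In this assay the change on this aromatic carbon, next to the ring nitrogen, gives an 88-fold higher number from compound 2 to compound 4 (1.94 log units; beyond the scatter) when diethylamino replaces 3-((isopropylcarbonyl)amino)pyrrolidin-1-yl, the largest step among the compounds that differ in one place. Set against 3-phenylpyrrolidin-1-yl, the same diethylamino group gives a 3.5-fold higher number from compound 1 to compound 4 (0.55 log units; beyond the scatter) as a modest step, so both substituted five-membered rings give lower numbers here than the open-chain group, the phenyl-bearing ring by far less. Nothing on record accounts for these differences.

The compounds shown leave open how much of the gap belongs to the five-membered ring and how much to what it carries, as none has a bare pyrrolidin-1-yl on this carbon. On these data alone, it also remains open how a free amine on that ring, or a piperidin-1-yl ring in its place, would stand against compound 2.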